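The compounds below may be only part of what the source reports. "The series", "measured", "known", "first", "only" and "open" are said of these compounds alone.

Going by the values given here, compound 1 `O=C(c1ccncc1)n1c(-c2cn(-c3ccccc3)nc2-c2ccc(F)cc2)nc2ccccc21` stands at the lowest of the two numbers so far in an ADME assay on HEK-293T cells (Homo sapiens) for cytotoxicity, read by MTT assay, with a stated time of 24 h (on this read-out lower numbers stand for higher toxicity in this test and higher numbers for lower toxicity in this test), compound 1 giving 151000 nM. Compound 2 `O=C(c1ccc(Cl)cc1)n1c(-c2cn(-c3ccccc3)nc2-c2ccc(F)cc2)nc2ccccc21` gives 179000 nM in this assay, a 1.2-fold higher number from compound 1 to compound 2 (0.07 log units; within the scatter). Compound 3 `Cc1ccc(-c2nn(-c3ccccc3)cc2-c2nc3ccccc3n2C(=O)c2ccncc2)cc1` differs from compound 1 in one place: methyl in place of fluoro on an aromatic carbon. Among the compounds with values here, the only measured step alters a different part of the shared core, so no measured step bears directly on this change; both numbers sit close together. Compound 3 is therefore expected to show no step beyond the scatter, a 1.1-fold higher number from compound 1 to compound 3 (0.03 log units; within the scatter). Compound 3 is estimated at 160000 nM, between 80000 nM and 320000 nM.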

Compound 3, half-maximal cytotoxic concentration: 154000 nM
Compound 3: middle estimate off by 1.0-fold (0.02 log units), on the high side; measured number inside the range.
By their numbers in this assay, from the lowest: compounds 1, 3 and 2 (each within the scatter of the next).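

In this assay, 4-methylphenyl in place of 4-fluorophenyl gives a 1.0-fold higher number from compound 1 to compound 3 (0.01 log units; within the scatter) and so stays within the scatter. Going by these compounds alone, this is the first measured step on this aromatic carbon, para to a large group, and at this position the number does not separate fluoro from methyl. No measured evidence bears on this result. Still open, as far as these compounds go, is whether an amine, a carboxylic acid or a longer chain such as butyl at this position would also stay within the scatter of compound 1.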